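The source may hold more compounds than are shown below. What is called first, only, known or untested is meant among the compounds shown, and "the series" means these compounds.

- Compound 1 `Cc1ccc(S(=O)(=O)c2nc3ccccc3nc2N2CCCC2)cc1`: > 50000 nM, a limit
- Compound 2 `COc1ccc(S(=O)(=O)c2nc3ccccc3nc2N2CCCC2)cc1`: > 50000 nM, a limit
- Compound 3 `O=S(=O)(c1ccc(F)cc1)c1nc2ccccc2nc1N1CCCC1`: 30100 nM

In a functional assay on KB cells (Homo sapiens) for cytotoxicity, read by MTT assay, with a stated time of 72 h (a higher number here means a weaker inhibitor, a lower number a stronger inhibitor), compound 2 gives only a limit, > 50000 nM. This is the limit of > 50000 nM in this assay, at which 2 of the 3 values shown sit.

Compound 4 `COc1ccc(S(=O)(=O)c2nc3ccccc3nc2N2CCCC(O)C2)cc1` has 3-hydroxypiperidin-1-yl in place of pyrrolidin-1-yl on an aromatic carbon, next to the ring nitrogen: 3-hydroxypiperidin-1-yl in place of pyrrolidin-1-yl on an aromatic carbon. Going by the values given here, none of the measured steps makes this change. They all exchange a different group, methyl, methoxy or fluoro, on an aromatic carbon, so they bear on it only indirectly. One of them is a step that the two limits leave unreadable from compound 1 to compound 2. Another is an at least 1.6-fold lower number from compound 2 to compound 3 (0.22 log units; that floor lies within the scatter), and a third is an at least 1.6-fold lower number from compound 1 to compound 3 (0.22 log units; that floor lies within the scatter).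

Among the compounds with values here, with no measured step at this place, no step beyond the scatter is expected in this assay, and no direction can be given. The expected step is a number no higher from compound 2 to compound 4 (the limit leaves the size open). For compound 4 the estimated value is 50000 nM, with an expected range from 20000 nM to 100000 nM.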

Compound 4, half-maximal inhibitory concentration: 2120 nM
Compound 4: the middle estimate sits 24-fold (1.37 log units) above what was measured; measured number outside the range, below it.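

In this assay, the aromatic carbon next to the ring nitrogen proves responsive to its substituent: 3-hydroxypiperidin-1-yl in place of pyrrolidin-1-yl gives an at least 23-fold lower number from compound 2 to compound 4 (1.37 log units; beyond the scatter). Going by these compounds alone, this is the first step in the set that reads as beyond the scatter, whereas the exchanges among methyl, methoxy and fluoro on an aromatic carbon gave only floors within the scatter or could not be read. The true size stays open, since the step starts from a limit: the limit of > 50000 nM in this assay, at which 2 of the 4 values shown sit.

The change swaps a five-membered ring for a six-membered one and adds a hydroxyl in a single move, so the compounds shown do not separate the two. On these data alone, whether plain piperidin-1-yl, morpholin-4-yl or an open-chain amine at this place would give a similar number also remains open.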